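This account rests on a few compounds, and the source may have more. Where it says the series, first, only, none or still open, it means among the compounds named here.

Working notes on the side chain at one oxygen on a saturated carbon, all on the shared core. Going by the values given here, in a functional assay on DU-145 cells (Homo sapiens) for cytotoxicity, read by MTT assay (a lower number here means a stronger inhibitor, a higher number a weaker inhibitor), compound 2 `CC(C)=CC[C@@H](OC[C@@H](C)O)C1=CC(=O)c2c(O)ccc(O)c2C1=O` gives 14300 nM, the only actual number so far. Compound 1 `CCCC(O)CC(=O)O[C@H](CC=C(C)C)C1=CC(=O)c2c(O)ccc(O)c2C1=O` reads > 100000 nM, which is a limit of the assay and not a number.

Among the compounds with values here, one measured step bears on the next change: an at least 6.9-fold lower number from compound 1 to compound 2 (0.84 log units; beyond the scatter), with 2-hydroxypropyl in place of (2-hydroxypentyl)carbonyl at that oxygen. Compound 3 `CC(=O)OCCC(=O)O[C@H](CC=C(C)C)C1=CC(=O)c2c(O)ccc(O)c2C1=O` changes the same place, with (2-acetoxyethyl)carbonyl in place of 2-hydroxypropyl on an oxygen on a saturated carbon.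

This restores a carbonyl-linked group of the kind carried by compound 1, so the measured step is read in reverse, with caution, as it is a single pair and the incoming chain differs. Going by an at least 6.9-fold lower number from compound 1 to compound 2 (0.84 log units; beyond the scatter), a move to a higher number beyond the scatter is expected in this assay, and compound 3 may also end up as a limit. The expected change is a 3.1-fold higher number from compound 2 to compound 3 (0.50 log units; beyond the scatter). For compound 3 the estimated value is 45000 nM, within an expected range of 15000 nM to 100000 nM.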

Compound 3, half-maximal inhibitory concentration: 15700 nM
Compound 3: middle estimate off by 2.9-fold (0.46 log units), on the high side; the range from low to high includes it.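

A carbonyl link at this oxygen is not enough on its own to give a weak reading in this assay: there is a 1.1-fold higher number from compound 2 to compound 3 (0.04 log units; within the scatter), even though (2-acetoxyethyl)carbonyl and 2-hydroxypropyl differ in heavy atoms and in their counted hydrogen-bond donors and acceptors. With the carbonyl link kept, what lies further out on the chain now separates two compounds: there is an at least 6.3-fold lower number from compound 1 to compound 3 (0.80 log units; beyond the scatter), with acetoxymethyl in place of 1-hydroxybutyl on a saturated chain carbon bound to a carbonyl carbon. The value of compound 1 is a limit of the assay and not a number, so the true size of that step stays open: the limit of > 100000 nM in this assay, at which 1 of the 3 values shown sits.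

Still open, going by these compounds, is whether the free hydroxyl or the chain length separates compound 1 from compound 3, as the two differ in both at once. Also open, on these data alone, is how an amine or a carboxylic acid at the end of a carbonyl-linked chain, or a longer chain ending in an acetoxy group, would read in this assay, and whether any side chain at this oxygen gives a number clearly lower than those of compound 2 and compound 3.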